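The source may hold more compounds than are shown below. What is called first, only, known or untested is meant among the compounds shown, and "the series" means these compounds.

Measured compounds and their values:
Compound 1 `CC(C)(C)C1CCc2nc(N)ncc2C1` gives 41%.
Compound 2 `Cc1ncc2c(n1)CCC(C(C)(C)C)C2` gives < 5%, which is a limit of the assay and not a number.
Compound 3 `CC(C)(C)c1nc(N)ncc1-c1ccccc1` gives 46%.

All three were tested in a functional assay on the whole organism for inhibition, with Rattus norvegicus as the target, with stated times of 1 h and 3.5 h, at a dose of 100 mg/kg by the oral route; on this read-out lower numbers stand for less inhibition and higher numbers for more inhibition at the one dose given (going by the name of the read-out). Compound 1 and compound 2 share one core and differ in one place: methyl in place of amino on an aromatic carbon. That change gave a number at least 36 percentage points lower from compound 1 to compound 2 (beyond the scatter). The value of compound 2 sits at the limit of < 5% in this assay, at which 1 of the 3 values shown sits. Compound 3 has a different core from compound 1; the difference between the two cores is not broken down here. The values of compound 1 and compound 3 lie within the scatter of each other, so nothing is said here about which number is higher.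

Compound 4 `Cc1ncc(-c2ccccc2)c(C(C)(C)C)n1` has not yet been measured in this assay. It differs from compound 3 in one place: methyl in place of amino on an aromatic carbon. This is the same kind of change as from compound 1 to compound 2, though the surroundings differ: in compound 1 the changed carbon belongs to a ring that is part of a fused or bridged system of two rings and is meta and para to a fused ring, whereas in compound 3 it is meta to a tert-butyl group and para to a group of 6 heavy atoms. Because the same kind of change gave a number at least 36 percentage points lower from compound 1 to compound 2 (beyond the scatter), a step of similar size is expected here, a number 38 percentage points lower from compound 3 to compound 4 (beyond the scatter). Compound 4 is therefore estimated to give 8%, between 0% and 25%, with a real chance that only a limit is reported.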

Compound 4, a percentage reported as inhibition, in the whole organism at one dose (the size of the read-out at that dose, not a potency): 22%
Estimate against measurement, compound 4: 14 percentage points below; the measured number falls inside the stated range.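

In this assay, methyl in place of amino on the carbon between two ring nitrogen atoms gave a number 24 percentage points lower from compound 3 to compound 4 (beyond the scatter), so the number falls on the core of compound 3 as it does on the core of compound 1. Compound 2 gives < 5%, which is a limit of the assay and not a number. The two steps therefore point the same way, but their sizes cannot be set against each other, and two cores do not make a rule for any other core in this series: the same change on two cores in this assay, a number at least 36 percentage points lower (beyond the scatter) from compound 1 to compound 2 and a number 24 percentage points lower (beyond the scatter) from compound 3 to compound 4; the limit leaves it open whether they differ.

Among the compounds shown, this carbon carries only amino or methyl, so it remains open how a hydroxyl group, a methylamino group or a dimethylamino group would read there on either core. On these data alone, it also remains open how the number would respond if the amino group stayed in place on the core of compound 3 and a longer chain took the place of the tert-butyl group.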